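Aryl swap at the saturated ring carbon: thiophene

A few compounds are considered here, and "the series" means these few. Any claim that something is new, unique, unknown or untested is made for them only; others in the source may bear on it.

For the measured compounds named here, compound 3 `CN1C(=O)C(c2ccccc2Br)N(C)c2nc(Nc3ccc(S(N)(=O)=O)cc3)ncc21` gives, in an assay on Sf9 cells for inhibition of serine/threonine-protein kinase 4 (Homo sapiens), read by luminescence and ADP-Glo, with a stated time of 1 h, in the presence of a further agent that is not named here (a lower number here means a stronger inhibitor, a higher number a weaker inhibitor), 57 nM, the second highest of the three numbers so far. It lies within the scatter of compound 2 `CN1C(=O)C(c2ccccc2C(F)(F)F)N(C)c2nc(Nc3ccc(S(N)(=O)=O)cc3)ncc21`, which gives 56 nM; the pair differs only by a 1.0-fold higher number from compound 2 to compound 3 (0.01 log units; within the scatter). Compound 1 `CC1C(=O)N(C)c2cnc(Nc3ccc(S(N)(=O)=O)cc3)nc2N1C`, with methyl on the saturated ring carbon, gives 313 nM; the step to the aryl analogue is a 5.5-fold lower number from compound 1 to compound 3 (0.74 log units; beyond the scatter), and a 5.6-fold lower number from compound 1 to compound 2 (0.75 log units; beyond the scatter) likewise.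

Compound 4 `CN1C(=O)C(c2cccs2)N(C)c2nc(Nc3ccc(S(N)(=O)=O)cc3)ncc21` is not yet measured. It differs from compound 3 by thiophen-2-yl in place of 2-bromophenyl on a saturated ring carbon. Going by the values given here, no measured step covers an exchange of one aromatic group for another at this carbon; the two bearings are the gain on going from methyl to either aryl group, and the bromo/trifluoromethyl exchange, which stayed within the scatter. A number between those of compound 1 and compound 3 is therefore expected. The step of a 1.9-fold higher number from compound 3 to compound 4 (0.29 log units; within the scatter) is expected to be modest and towards a higher number, if beyond the scatter at all. For compound 4 a value of 110 nM is estimated, with a range from 40 nM to 300 nM.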

Compound 4, half-maximal inhibitory concentration: 88 nM
For compound 4 the middle estimate is 1.3-fold (0.10 log units) above the measured one, within the range that was stated.
By their numbers in this assay, from the lowest: compounds 2, 3 and 4 (each within the scatter of the next); then compound 1.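

In this assay the step of a 1.5-fold higher number from compound 3 to compound 4 (0.19 log units; within the scatter) and the step of a 1.6-fold higher number from compound 2 to compound 4 (0.20 log units; within the scatter) both stay within the scatter, so at the saturated ring carbon a five-membered aromatic ring with one hetero atom reads the same as either substituted phenyl group. The step of a 3.6-fold lower number from compound 1 to compound 4 (0.55 log units; beyond the scatter) is beyond the scatter, which shows that among these compounds the gain over methyl needs neither a six-membered aromatic ring nor a bromo or trifluoromethyl substituent. Nothing measured here explains these steps.

The compounds shown leave open whether a non-aromatic group at this carbon, such as cyclohexyl, a longer alkyl chain or a chain ending in an amine or a carboxylic acid, would keep the gain over methyl. They also leave open whether unsubstituted phenyl or thiophen-3-yl would give a number within the scatter of compound 4.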